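Hydroxy for methoxy on the aryl of compound 1

The compounds below may be only part of what the source reports. "The series", "measured", "known", "first", "only" and "open" are said of these compounds alone.

Among the measured compounds shown here, compound 1 `COc1cc(/C=C/C(C)=O)ccc1OCc1cn(-c2ccccc2OC)nn1` is the most potent of the two compounds measured so far in a functional assay on PC-3 cells (Homo sapiens) for antiproliferative activity, read by MTT assay, with a stated time of 48 h; on this read-out higher numbers stand for weaker inhibition and lower numbers for stronger inhibition: in this assay compound 1 gives 2050 nM. For the measured compounds named here, the only other measured member, compound 2 `CCOC(=O)c1ccc(-n2cc(COc3ccc(/C=C/C(C)=O)cc3OC)nn2)cc1`, is much weaker, giving 59200 nM in this assay, a gap well beyond the scatter; as the two differ in more than one place, no single step between them can be read off.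

Compound 3 `COc1cc(/C=C/C(C)=O)ccc1OCc1cn(-c2ccccc2O)nn1` keeps the shared core of compound 1 and differs from it in one place (hydrogen in place of methyl on an oxygen on an aromatic ring). Going by the values given here, no measured pair isolates this change, and the gap from compound 1 to compound 2 involves other differences, so it gives no direct guide.

With nothing in the series to anchor the change, the step from compound 1 to compound 3 is expected to be a 1.2-fold higher number from compound 1 to compound 3 (0.09 log units; within the scatter), that is, no movement beyond the scatter in this assay. Compound 3 is therefore estimated to give 2500 nM in this assay, with a likely range from 800 nM to 8000 nM.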

Compound 3, half-maximal inhibitory concentration: 59200 nM
The estimate for compound 3 lay 24-fold (1.37 log units) below the measured number; the measured number lies above the stated range.
By their numbers in this assay, from the lowest: compound 1; then compounds 2 and 3 (each within the scatter of the next).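

In this assay, hydrogen in place of methyl on an oxygen on an aromatic ring, that is, 2-methoxyphenyl to 2-hydroxyphenyl, gives a 29-fold higher number from compound 1 to compound 3 (1.46 log units; beyond the scatter). Among the compounds shown here, this is the first step that isolates one change, and it shows that this position is far from indifferent: the loss of a single carbon, with the rest of compound 1 kept, removes most of the antiproliferative activity seen on this read-out. No measurement on hand accounts for the size of this step.

On these data alone, it remains open whether the methyl itself matters or whether the free hydroxy is what costs activity, and an ethyl or a longer chain on that oxygen, or an amine in place of the methoxy, would help to separate the two. For the compounds shown here, with only this one pair, it is also open whether the same change would give a step of similar size on other aryl groups, such as the one in compound 2.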